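A Sec-Butyl Branch on an Acid at the Floor of the Scale

The compounds below may be only part of what the source reports. "The series", "measured", "known", "first", "only" and "open" are said of these compounds alone.

Two measured compounds share one core. Compound 1 `O=C(O)CNc1nc(-c2ccccc2)nc2ccc(Br)cc12` carries a bromo on an aromatic carbon, and compound 2 `O=C(O)CNc1nc(-c2ccccc2)nc2ccc(I)cc12` has an iodo in its place. In a functional assay on the whole organism (strain Wistar) for inhibition, with Rattus norvegicus as the target, read by paw edema, at a dose of 100 mg/kg by the oral route (on this read-out higher numbers stand for more inhibition at the one dose given (going by the name of the read-out) and lower numbers for less inhibition), compound 1 gives 0%, and in this assay compound 2 gives 0%. Among the compounds with values here, the only step measured so far, no change at the digits printed from compound 1 to compound 2 (within the scatter), is flat: exchanging one halogen for the other leaves the read-out unmoved. Compound 2 therefore stands at the floor of the scale, level with compound 1.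

Compound 3 `CC[C@H](C)[C@H](Nc1nc(-c2ccccc2)nc2ccc(I)cc12)C(=O)O` differs from compound 2 by a single change: sec-butyl in place of hydrogen on a saturated chain carbon bound to a carbonyl carbon and a nitrogen on an aromatic ring. Within the data shown here, no measured step touches this part of the molecule; the one known step concerns only the halogen, not the saturated chain carbon bound to a carbonyl carbon and a nitrogen on an aromatic ring. There is thus nothing in the data to point to a rise or a fall in this assay beyond the scatter, and a read-out near the floor remains the plainest expectation. Compound 3 is estimated at 10%, with a likely range from 0% to 35%, meaning an expected step of a number 10 percentage points higher from compound 2 to compound 3 (within the scatter).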

Compound 3, a percentage reported as inhibition, in the whole organism at one dose (the size of the read-out at that dose, not a potency): 0%
Compound 3: the middle estimate sits 10 percentage points above what was measured; the measured number falls inside the stated range.
By their numbers in this assay, from the lowest: compounds 1, 2 and 3 (each within the scatter of the next).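

In this assay, within the data shown here, placing sec-butyl on a saturated chain carbon bound to a carbonyl carbon and a nitrogen on an aromatic ring gives the first measured step at this position (no change at the digits printed from compound 2 to compound 3 (within the scatter)). The earlier step concerned only the halogen, whereas this one shows that going from carboxymethyl to 1-carboxy-2-methylbutyl does not lift the read-out off the floor of the scale at the one dose given. A read-out at the floor has no room to register a fall, so this shows only that the branch brings no measurable gain, and no measurement at hand offers an explanation for the flat result.

On these data alone, with all three compounds at the floor of this assay, it remains open whether a methyl or a benzyl group on this same carbon would raise the read-out. As far as these compounds go, it is equally open whether a methyl ester or a primary amide in place of the carboxylic acid, or a chloro in place of the iodo, would move the read-out at all.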